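Halogen swap on the anilino ring of an acrylamide series

The source may report more compounds than this note shows. Statements on the series, on what has been measured and on what is new or still open speak of the compounds shown alone.

Two compounds share a core carrying an acrylamide and an anilino-substituted ring. Compound 1 `C=CC(=O)Nc1cccc(NC(=O)CSc2nc(Nc3cccc(OC)c3)c3ccccc3n2)c1` gives 12900 nM in a functional assay on MDA-MB-231 cells (Homo sapiens) for inhibition, read by MTT assay, with a stated time of 72 h; on this read-out higher numbers stand for weaker inhibition and lower numbers for stronger inhibition. Compound 2 `C=CC(=O)Nc1cccc(NC(=O)CSc2nc(Nc3ccc(Cl)cc3)c3ccccc3n2)c1` gives 10300 nM in this assay. The step of a 1.3-fold lower number from compound 1 to compound 2 (0.10 log units; within the scatter) changes only the aryl group on the ring nitrogen and stays within the scatter, so compound 2, although it holds the lowest of the two numbers, cannot be set apart from compound 1.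

Compound 3 `C=CC(=O)Nc1cccc(NC(=O)CSc2nc(Nc3ccc(F)c(Cl)c3)c3ccccc3n2)c1` is not yet measured. It differs from compound 2 by 3-chloro-4-fluorophenyl in place of 4-chlorophenyl on a nitrogen on an aromatic ring. Going by the values given here, the only measured step that touches this position is a 1.3-fold lower number from compound 1 to compound 2 (0.10 log units; within the scatter), which exchanged one aryl group for another at the same nitrogen and produced no shift beyond the scatter. On that basis no step beyond the scatter is expected from compound 2 to compound 3 in this assay, and the expected step is a 1.0-fold lower number from compound 2 to compound 3 (0.01 log units; within the scatter). Compound 3 is therefore estimated to give 10000 nM in this assay, with an expected range from 4000 nM to 25000 nM.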

Compound 3, half-maximal inhibitory concentration: 10600 nM
Compound 3: middle estimate off by 1.1-fold (0.03 log units), on the low side, within the range that was stated.
By their numbers in this assay, from the lowest: compounds 2, 3 and 1 (each within the scatter of the next).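

In this assay, the step of a 1.0-fold higher number from compound 2 to compound 3 (0.01 log units; within the scatter) is a second aryl exchange at the nitrogen on an aromatic ring, and like the first it stays within the scatter. This time the change keeps the 4-position halogen pattern out of the picture only in part: 4-chlorophenyl gives way to 3-chloro-4-fluorophenyl, so the ring gains a second halogen, and the read-out does not separate the two compounds. The step of a 1.2-fold lower number from compound 1 to compound 3 (0.09 log units; within the scatter) is also within the scatter, so 3-methoxyphenyl, 4-chlorophenyl and 3-chloro-4-fluorophenyl cannot be told apart at this position, and nothing at hand offers an explanation for this flat result.

From the compounds shown here alone, all three compounds carry a substituted phenyl ring on this nitrogen, so it remains open whether a carboxylic acid or a dimethylamino group on that ring, or a pyridine ring in its place, would produce a step beyond the scatter. All three also keep the acrylamide, which leaves open how the read-out would respond if a saturated propanamide stood there instead.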